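The source may report more compounds than this note shows. Statements on the series, on what has been measured and on what is new or still open speak of the compounds shown alone.

Measured so far:
compound 1 `C=CC(=O)N1C(=O)CC(c2cccc(Cl)c2)Sc2ccccc21`: 93100 nM
compound 2 `C=CC(=O)N1C(=O)CC(c2ccc(C(=O)OC)cc2)Sc2ccccc21`: 102000 nM

In a functional assay on HL-60 cells (Homo sapiens) for cytotoxicity, read by CCK-8 assay, with a stated time of 24 h (a higher number here means a weaker inhibitor, a lower number a stronger inhibitor), compound 1 gives 93100 nM, the lowest of the two numbers. Compound 2 gives 102000 nM, which lies within the scatter of compound 1, so the two cannot be ordered. Compound 3 `C=CC(=O)N1C(=O)CC(C)Sc2ccccc21` is not yet measured; it differs from compound 1 by methyl in place of 3-chlorophenyl on a saturated ring carbon. For the measured compounds named here, no step between measured compounds is known, so the size of this change has no precedent here. The expectation is a modest step toward a higher number in this assay, possibly none beyond the scatter, a 1.6-fold higher number from compound 1 to compound 3 (0.21 log units; within the scatter). Compound 3 is estimated at 150000 nM, between 60000 nM and 400000 nM.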

Compound 3, half-maximal inhibitory concentration: 199000 nM
Compound 3: the middle estimate sits 1.3-fold (0.12 log units) below what was measured; the range from low to high includes it.
By their numbers in this assay, from the lowest: compounds 1, 2 and 3 (each within the scatter of the next, the first and the last beyond it).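

In this assay, for the compounds shown here, the change from 3-chlorophenyl to methyl on this saturated ring carbon, next to the ring sulfur, gives the first sized step at this position (a 2.1-fold higher number from compound 1 to compound 3 (0.33 log units; beyond the scatter)). The step is modest, so replacing the aromatic ring with methyl shifts the number only a little. Nothing available explains this shift.

Going by these compounds, what a longer chain, an amine or a carboxylic acid would do on this carbon remains open. So does how much of the step belongs to the chlorine and how much to the ring itself.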